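Methyl at the amide-bearing chain carbon in a dienamide series

A few compounds are considered here, and "the series" means these few. Any claim that something is new, unique, unknown or untested is made for them only; others in the source may bear on it.

Compound 1 `O=C(/C=C/C=C(c1cccc(F)c1)c1cccc(F)c1)NCCCCc1cccnc1` is the reference point of this set. In a functional assay with platelet-activating factor receptor (Cavia porcellus) as the target (a lower number here means that less compound is needed, a higher number that more compound is needed for the effect), compound 1 gives 0.34 mg/kg. Compound 2 `CC/C(=C\C=C\C(=O)N[C@H](C)CCCc1cccnc1)c1ccc(OC)cc1` and compound 3 `COc1ccc(/C(=C/C=C/C(=O)N[C@H](C)CCCc2cccnc2)C(C)C)cc1` carry a different core, and how the core of compound 1 differs from the core of compound 2 is not broken down here. Compound 2 gives 0.68 mg/kg in this assay, and compound 3 gives 0.41 mg/kg. Against compound 1, both compound 2 and compound 3 lie within the scatter, so no order among the three is read from these numbers.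

Going by the values given here, the one counted pair among the measured compounds is methyl in place of hydrogen on a saturated chain carbon bound to a double-bonded chain carbon and a saturated chain carbon, which made the step of a 1.7-fold lower number from compound 2 to compound 3 (0.22 log units; within the scatter). The unmeasured compound 4 `C[C@H](CCCc1cccnc1)NC(=O)/C=C/C=C(c1cccc(F)c1)c1cccc(F)c1` is made from compound 1 by methyl in place of hydrogen on a saturated chain carbon bound to an amide-type nitrogen and a saturated chain carbon. This is the same kind of change, a methyl entering where a hydrogen leaves, but the place is not identical: in compound 3 the saturated chain carbon is bound to a double-bonded chain carbon and a saturated chain carbon, while in compound 4 it is bound to an amide-type nitrogen and a saturated chain carbon. Compound 2 and compound 3 already carry a methyl at a carbon of that second kind, and neither stands apart from compound 1. Nothing in the set shows a methyl at either place moving the number beyond the scatter. Compound 4 is therefore expected to make the step of a 1.1-fold lower number from compound 1 to compound 4 (0.05 log units; within the scatter), set beside a 1.7-fold lower number from compound 2 to compound 3 (0.22 log units; within the scatter). The estimate for compound 4 in this assay is 0.3 mg/kg, expected to fall between 0.12 mg/kg and 0.75 mg/kg.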

Compound 4, dose for 50% inhibition: 0.22 mg/kg
Beside the measured number, compound 4's estimate is 1.4-fold (0.13 log units) above it; low and high end bracket the measured number.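

Methyl in place of hydrogen on a saturated chain carbon bound to an amide-type nitrogen and a saturated chain carbon gives, in this assay, a small step (a 1.5-fold lower number from compound 1 to compound 4 (0.19 log units; within the scatter)), so on the core of compound 1 this methyl leaves the number where repeated measurement could place it anyway. The two methyl steps agree, which means the change carries from one core to the other without a detectable difference, but neither step stands clear of the scatter, so there is no real effect here to be carried, only the absence of one on both cores, and the two methyl groups also do not sit on the same kind of carbon, the earlier one being on a saturated chain carbon bound to a double-bonded chain carbon and a saturated chain carbon. The comparison of the two steps reads: the same change on two cores in this assay, a 1.7-fold lower number (0.22 log units; within the scatter) from compound 2 to compound 3 and a 1.5-fold lower number (0.19 log units; within the scatter) from compound 1 to compound 4, 1.1-fold (0.03 log units) apart, within the scatter of two such steps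

Still open, as far as these compounds go, is whether an ethyl group, a hydroxymethyl group or a second methyl on the amide-bearing chain carbon would move the number beyond the scatter. Also open, from the compounds shown here alone, is whether the methyl stays without visible effect on a core carrying a carboxylic acid or an amine.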